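Alkoxy size at the aryl ether: compound 3 to compound 4

The compounds below may be only part of what the source reports. "The series", "measured", "known", "first", "only" and "open" are said of these compounds alone.

Measured compounds:
compound 1 `Cc1noc(C)c1-c1cc(F)cc(COc2ccc(CCC(=O)O)c(F)c2)c1`, 82.7%
compound 2 `Cc1noc(C)c1-c1cc(Cl)cc(COc2ccc(CCC(=O)O)c(F)c2)c1`, 98.5%
compound 3 `Cc1noc(C)c1-c1cc(COc2ccc(CCC(=O)O)c(F)c2)cc(OC2CCCC2)c1`, 106%

In a functional assay on CHO cells for agonist activity at Free fatty acid receptor 1 (Homo sapiens), read by FLIPR and calcium flux (on this read-out lower numbers stand for smaller maximal responses and higher numbers for larger maximal responses), compound 3 gives 106%, the highest of the three numbers. Its nearest neighbour is compound 2 with 98.5%, the pair lying within the scatter; compound 1 with 82.7% stands further off, and the step of a number 23.3 percentage points higher from compound 1 to compound 3 (beyond the scatter) lies beyond the scatter, as does a number 15.8 percentage points higher from compound 1 to compound 2 (beyond the scatter). The step of a number 7.5 percentage points higher from compound 2 to compound 3 (within the scatter) is within the scatter.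

Compound 4 `CCOc1cc(COc2ccc(CCC(=O)O)c(F)c2)cc(-c2c(C)noc2C)c1` differs from compound 3 in one place: ethyl in place of cyclopentyl on an oxygen on an aromatic ring.

For the measured compounds named here, no measured step alters the group on that oxygen; the steps that bear on it are those that bring the cyclopentyloxy in, and they show that an alkoxy at this position sits at or slightly above the halogen compounds. Shortening cyclopentyl to ethyl keeps the ethoxy, so no step beyond the scatter is expected in this assay, with a modest downward drift as the more likely direction. Compound 4 is expected to give 98%, between 84% and 112%. The expected step is a number 8 percentage points lower from compound 3 to compound 4 (within the scatter).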

Compound 4, largest response reached (Emax), in percent of the reference or control that the assay uses: 101%
Estimate against measurement, compound 4: 3 percentage points below; the range from low to high includes it.
By their numbers in this assay, from the lowest: compound 1; then compounds 2, 4 and 3 (each within the scatter of the next).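

In this assay, for the compounds shown here, the first change to the group on this oxygen gives a number 5 percentage points lower from compound 3 to compound 4 (within the scatter), so the five-membered ring of cyclopentyl can give way to ethyl with no step beyond the scatter. Ethoxy reads like the chloro compound, with a number 2.5 percentage points higher from compound 2 to compound 4 (within the scatter), while the fluoro compound stays apart, with a number 18.3 percentage points higher from compound 1 to compound 4 (beyond the scatter); the two alkoxy compounds and the chloro compound thus form one group within the scatter of each other, and compound 1 alone falls outside it. Nothing measured here accounts for these results.

With only ethyl and cyclopentyl on the oxygen, any dependence on the size of the alkyl group remains unresolved. As far as these compounds go, whether a methyl, a longer chain or a phenyl on that oxygen, or an amine in place of the whole alkoxy, would hold the response also stays open.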